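This account rests on a few compounds, and the source may have more. Where it says the series, first, only, none or still open, it means among the compounds named here.

Measured so far in an assay on isolated protein for inhibition of leukotriene B4 receptor 1 (Homo sapiens), tested at 10 uM; a higher number here means more inhibition at the concentration tested (going by the name of the read-out), a lower number less inhibition:
compound 1, `CCc1cc(C(C)=O)c(O)cc1OCCCCC(C)(C)C#N` — compound 1 gives 79%
compound 2, `CCc1cc(C(C)=O)c(O)cc1OCCCCCCC(C)(C)C#N` — compound 2 gives 65%
compound 3, `CCc1cc(C(C)=O)c(O)cc1OCCCC(C)(C)c1nnn[nH]1` — compound 3 gives 100%

Compound 3 stands highest of the three numbers in this assay. Its nearest neighbour is compound 1, and that gap, a number 21 percentage points higher from compound 1 to compound 3 (beyond the scatter), lies beyond the scatter. The gap to compound 2, a number 35 percentage points higher from compound 2 to compound 3 (beyond the scatter), is larger still. Among the two nitrile compounds themselves, the longer chain in compound 2 gave a number 14 percentage points lower from compound 1 to compound 2 (beyond the scatter).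

The next compound, compound 4, `CCc1cc(C(C)=O)c(O)cc1OCCCCCCSC`, differs from compound 3 in one place: 3-(methylsulfanyl)propyl in place of 1-(1H-tetrazol-5-yl)-1-methylethyl on a saturated chain carbon, three bonds along the chain from an oxygen on an aromatic ring. What leaves is the group whose arrival, in both steps toward compound 3, brought the rise; what enters is a chain bearing a sulfur, with no ring, no hydrogen-bond donor and only one acceptor. Both steps into compound 3 bear on this change, since each replaced a nitrile-bearing chain with the tetrazole-bearing group and each rose beyond the scatter. Removing that group again is therefore expected to lower the number, and the step is estimated as a number 50 percentage points lower from compound 3 to compound 4 (beyond the scatter), a modest to large fall rather than none. Compound 4 is expected to give 50% in this assay, within a range from 25% to 75%.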

Compound 4, a percentage reported as inhibition, at one concentration (the size of the read-out at that concentration, not a potency): 71%
Compound 4: the middle estimate sits 21 percentage points below what was measured; the measured number falls inside the stated range.
By their numbers in this assay, from the lowest: compounds 2, 4 and 1 (each within the scatter of the next, the first and the last beyond it); then compound 3.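

In this assay, the place three bonds along the chain from an oxygen on an aromatic ring now shows that the gain with 1-(1H-tetrazol-5-yl)-1-methylethyl also holds against a chain ending in sulfur rather than a nitrile, the change to 3-(methylsulfanyl)propyl giving a number 29 percentage points lower from compound 3 to compound 4 (beyond the scatter) in the inhibition read at one concentration. The methylsulfanyl end does not separate from either nitrile chain, with a number 6 percentage points higher from compound 2 to compound 4 (within the scatter) on one side and a number 8 percentage points lower from compound 1 to compound 4 (within the scatter) on the other, even though the two nitrile compounds themselves stand apart beyond the scatter. Among these four compounds, then, compound 3 alone stands clear of all the others, and the one gap among the rest beyond the scatter is the one between compound 1 and compound 2.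

A carboxylic acid or a primary amide at this place, or the 1H-tetrazol-5-yl group on a longer chain, would test whether the gain belongs to the tetrazole ring or to something more general in that end of the chain. Why the number drops on leaving the tetrazole is not told by any measurement available here.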